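This account rests on a few compounds, and the source may have more. Where it says the series, first, only, none or still open, it means among the compounds named here.

Measured so far:
compound 1, `O=C(CN1CCC(c2cccc[n+]2[O-])CC1)Nc1ccc(F)cc1F`, 103 nM;
compound 2, `COc1cc(C(=O)NCN2CCC(c3cccc[n+]3[O-])CC2)ccc1Cl`, 159 nM;
compound 3, `Cc1cccc(NC(=O)CN2CCC(c3cccc(F)c3)CC2)c1`, 512 nM.

Of the compounds shown here, three have been measured in a functional assay on HEK293 cells for agonist activity at D(4) dopamine receptor (Homo sapiens), read by FLIPR; a lower number here means that less compound is needed, a higher number that more compound is needed for the effect. Compound 1 gives the lowest number of the three. Its nearest neighbour in the numbers is compound 2, which is within the usual scatter of compound 1, so the two cannot be told apart in this assay. Compound 3 stands furthest away, beyond the scatter, and so needs clearly more compound than compound 1 for the same effect. Compound 3 also differs from compound 1 in more than one place, so its gap cannot be tied to any single change.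

The step considered here goes from compound 1 to the unmeasured compound 4, `O=C(CN1CCC(c2cccc[n+]2[O-])CC1)Nc1cccc(F)c1`. The difference between the two is counted as 3-fluorophenyl in place of 2,4-difluorophenyl on an amide-type nitrogen. The shared core is kept, and the change sits only on the group carried by the amide-type nitrogen. Among the measured compounds shown here, no directly comparable pair among the measured compounds shows what such a change does in this assay. With one fluorine fewer on the ring, a small rise in the number is expected, but it may well stay within the scatter. The expected step from compound 1 to compound 4 is a 1.9-fold higher number from compound 1 to compound 4 (0.29 log units; within the scatter). For compound 4 the estimate is 200 nM, with a range from 70 nM to 600 nM.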

Compound 4, half-maximal effective concentration: 160 nM
Estimate against measurement, compound 4: 1.3-fold (0.10 log units) above, within the range that was stated.
By their numbers in this assay, from the lowest: compounds 1, 2 and 4 (each within the scatter of the next); then compound 3.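

In this assay, among the compounds shown here, compounds 1 and 4 form the first pair that differs in one place, and it tests the group on the amide-type nitrogen: 3-fluorophenyl in place of 2,4-difluorophenyl gives a 1.6-fold higher number from compound 1 to compound 4 (0.19 log units; within the scatter). With the shared core kept, this position therefore accepts the exchange of a ring with two fluorines for a ring with one, and the assay cannot separate the outcome from repeated measurement. Nothing available bears on why the step has this size.

The two groups differ in both the number and the placing of their fluorines, so this single pair cannot show what either difference does alone. It also leaves open what happens at this position with a plain phenyl, or when the ring gives way to a carboxylic acid, an amine or a longer chain.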